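Swapping a halogen at the edge of the benzyl group

The source may hold more compounds than are shown below. What is called first, only, known or untested is meant among the compounds shown, and "the series" means these compounds.

Of the compounds shown here, three sharing one core have been measured in a functional assay on HEK293 cells for agonist activity at G-protein coupled receptor 39 (Homo sapiens), read by scintillation proximity assay and inositol phosphate accumulation, with a stated time of 75 min, in the presence of a further agent that is not named here; a lower number here means that less compound is needed, a higher number that more compound is needed for the effect. Compound 1 `Cc1nn(-c2ncnc3nc[nH]c23)c2c1C(OCc1ccccc1F)CC(=O)N2` gives 4 nM, which is the second highest of the three numbers: compound 3 `Cc1nn(-c2ncnc3nc[nH]c23)c2c1C(OCCc1ccccc1)CC(=O)N2` gives 3 nM, and compound 2 `Cc1nn(-c2ncnc3nc[nH]c23)c2c1C(OCc1ccccc1C#N)CC(=O)N2` gives 8 nM. Compound 4 `Cc1nn(-c2ncnc3nc[nH]c23)c2c1C(OCc1ccccc1Cl)CC(=O)N2` is the new member; it differs from compound 1 by chloro in place of fluoro on an aromatic carbon, on an aromatic carbon of a six-membered aromatic ring of carbon only, ortho to a large group.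

Among the compounds with values here, two measured steps touch the same spot. Exchanging the fluoro for cyano gave a 2.0-fold higher number from compound 1 to compound 2 (0.30 log units; within the scatter), and replacing the 2-fluorophenyl with benzyl gave a 1.3-fold lower number from compound 1 to compound 3 (0.12 log units; within the scatter). Both changes at this position left the number within the scatter, so a switch to chloro is expected to behave the same way, with no step beyond the scatter in this assay in either direction. Compound 4 is therefore estimated at 5 nM, with a range from 2 nM to 12 nM, meaning an expected step of a 1.3-fold higher number from compound 1 to compound 4 (0.10 log units; within the scatter).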

Compound 4, half-maximal effective concentration: 2 nM
Estimate against measurement, compound 4: 2.5-fold (0.40 log units) above; the measured number falls inside the stated range.
By their numbers in this assay, from the lowest: compounds 4, 3, 1 and 2 (each within the scatter of the next, the first and the last beyond it).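

Putting chloro in place of fluoro on the aromatic carbon ortho to a large group gives a 2.0-fold lower number from compound 1 to compound 4 (0.30 log units; within the scatter), and changing from the benzyl of compound 3 to the 2-chlorophenyl gives a 1.5-fold lower number from compound 3 to compound 4 (0.18 log units; within the scatter), so neither step separates these compounds. Exchanging the nitrile for chloro gives a 4.0-fold lower number from compound 2 to compound 4 (0.60 log units; beyond the scatter), which makes compound 4 the second compound, after compound 3, to stand apart from compound 2 beyond the scatter. No independent measurement among the data shown bears on why the numbers fall this way.

From the compounds shown here alone, it remains open whether bromo, methoxy or an amine on this same aromatic carbon would stay within the scatter of compound 4. The compounds shown also leave open how chloro would read on any other carbon of this ring.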